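Swapping Methoxy for Trifluoromethyl on a Hydroxamic Acid Core

This account rests on a few compounds, and the source may have more. Where it says the series, first, only, none or still open, it means among the compounds named here.

Two hydroxamic acids built on a shared core have been measured in a functional assay on PC-3 cells (Homo sapiens) for antiproliferative activity; on this read-out lower numbers stand for stronger inhibition of growth and higher numbers for weaker inhibition of growth. Compound 1 `COc1cccc(CN2CC=C(CCC(=O)NO)C2=O)c1` gives 3890 nM in this assay. Compound 2 `COc1ccccc1CCCN1CC=C(CCC(=O)NO)C1=O` gives 3510 nM in this assay. Compound 1 holds the higher of the two numbers, but the gap to its nearest neighbour, compound 2, lies within the scatter, so the two values tell the same story and neither compound can be ranked over the other.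

Compound 3 `O=C(CCC1=CCN(Cc2cccc(C(F)(F)F)c2)C1=O)NO` has not yet been measured in this assay. It differs from compound 1 in one place: trifluoromethyl in place of methoxy on an aromatic carbon. Going by the values given here, no single change of this kind has been measured among the compounds at hand, so there is no measured step to lean on. Because compound 1 gives 3890 nM and compound 2 gives 3510 nM within the scatter of each other, the step from compound 1 to compound 3 is expected to be small, a 1.1-fold lower number from compound 1 to compound 3 (0.05 log units; within the scatter), with no clear direction beyond the scatter. Compound 3 is therefore estimated to give 3500 nM in this assay, within a range from 1200 nM to 10000 nM.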

Compound 3, concentration for 50% growth inhibition: 880 nM
The estimate for compound 3 lay 4.0-fold (0.60 log units) above the measured number; measured number outside the range, below it.
By their numbers in this assay, from the lowest: compound 3; then compounds 2 and 1 (each within the scatter of the next).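

Trifluoromethyl in place of methoxy on an aromatic carbon, meta to a large group, gives a 4.4-fold lower number from compound 1 to compound 3 (0.65 log units; beyond the scatter) in this assay. This is the only change at a single place among the compounds shown, and it shows that this position on the six-membered aromatic ring is not indifferent to the group it carries, something the two earlier compounds, which differ in more than one place, could not reveal. Nothing measured here explains the step, so it cannot be tied to any property of either group.

Going by these compounds, it remains open whether the lower number belongs to trifluoromethyl itself or would also follow other replacements of methoxy at this place, such as a chlorine atom, a nitrile or a plain hydrogen. Also unresolved is whether the same swap would carry over to the longer chain of compound 2, where a methoxy group also sits on an aromatic ring, or whether the step holds only for the shorter link of compound 1.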